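Aryl amide variation on the shared core: compound 4

The source may hold more compounds than are shown below. What is called first, only, known or untested is meant among the compounds shown, and "the series" means these compounds.

Compound 1 `Cc1cccc(NC(=O)C2(C(=O)Nc3ccc(Nc4ncc5cc(C(=O)N(C)C)n(C6CCCC6)c5n4)cc3)CC2)c1` carries a 3-methylphenyl on the amide-type nitrogen of the shared core. In a functional assay on A549 cells (Homo sapiens) for inhibition, read by CCK-8 assay, with a stated time of 72 h, tested at 10 uM (on this read-out lower numbers stand for less inhibition of growth and higher numbers for more inhibition of growth at the one concentration tested), compound 1 gives 86.1%, the lowest of the three numbers recorded, though the nearest neighbour is within the scatter. Compound 2 `CN(C)C(=O)c1cc2cnc(Nc3ccc(NC(=O)C4(C(=O)Nc5ccccc5F)CC4)cc3)nc2n1C1CCCC1` gives 88.6% in this assay, and compound 3 `CN(C)C(=O)c1cc2cnc(Nc3ccc(NC(=O)C4(C(=O)Nc5ccc(Br)cc5)CC4)cc3)nc2n1C1CCCC1` gives 90.3%. The three steps are all small: a number 2.5 percentage points higher from compound 1 to compound 2 (within the scatter), a number 4.2 percentage points higher from compound 1 to compound 3 (within the scatter) and a number 1.7 percentage points higher from compound 2 to compound 3 (within the scatter). Compound 4 `Cc1ccc(NC(=O)C2(C(=O)Nc3ccc(Nc4ncc5cc(C(=O)N(C)C)n(C6CCCC6)c5n4)cc3)CC2)cc1` is the next member, and the change from compound 1 is 4-methylphenyl in place of 3-methylphenyl on an amide-type nitrogen.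

All three measured steps swap the aryl group on this amide-type nitrogen, and none moves the read-out beyond the scatter, so the same is expected here. Among the measured compounds shown here, no step directly compares a 3-methylphenyl with a 4-methylphenyl, so the expectation rests on the indifference of the three steps to the aryl group. The step is estimated as a number 0.9 percentage points higher from compound 1 to compound 4 (within the scatter), none beyond the scatter. In this assay compound 4 is expected to give 87%, within a range of 78% to 94%.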

Compound 4, percent growth inhibition at one concentration: 90.6%
Estimate against measurement, compound 4: 3.6 percentage points below; the measured number falls inside the stated range.
By their numbers in this assay, from the lowest: compounds 1, 2, 3 and 4 (each within the scatter of the next).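

In this assay, 4-methylphenyl in place of 3-methylphenyl on the amide-type nitrogen gives a number 4.5 percentage points higher from compound 1 to compound 4 (within the scatter), so a change in methyl placement alone, with the same atoms, also stays within the scatter. Methyl in place of bromo on an aromatic carbon gives a number 0.3 percentage points higher from compound 3 to compound 4 (within the scatter), and 4-methylphenyl in place of 2-fluorophenyl gives a number 2 percentage points higher from compound 2 to compound 4 (within the scatter), so the four aryl groups shown cannot be told apart at this one concentration. Nothing available explains this indifference to the aryl group.

Open, as far as these compounds go, is whether a different group on this nitrogen, such as a cyclohexyl, a benzyl, or a phenyl carrying a carboxylic acid or an amine, would move the read-out beyond the scatter. Also open, from the compounds shown here alone, is whether compounds 1 to 4 would separate across a full concentration series.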